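The source may hold more compounds than are shown below. What is called first, only, known or untested is meant among the compounds shown, and "the series" means these compounds.

Working notes. The series shares one core, carried by compound 1 `COc1ccc(C(=O)/C=C/c2ccc(-c3ccccc3)cc2)c2c1C=CC(C)(C)O2`, compound 2 `COc1ccc(C(=O)/C=C/c2ccc([N+](=O)[O-])cc2)c2c1C=CC(C)(C)O2` and compound 3 `COc1ccc(C(=O)/C=C/c2cccc(C(F)(F)F)c2)c2c1C=CC(C)(C)O2`, each differing only in one substituent on an aromatic ring. In a functional assay on SW-620 cells (Homo sapiens) for antiproliferative activity, read by MTT assay, with a stated time of 24 h (on this read-out lower numbers stand for stronger inhibition and higher numbers for weaker inhibition), compound 1 gives > 10000 nM, which is a limit of the assay rather than a number (the limit of > 10000 nM in this assay, at which 1 of the 3 values shown sits). Compound 2 gives 3520 nM in this assay. Within the data shown here, the only step between measured compounds, an at least 2.8-fold lower number from compound 1 to compound 2 (0.45 log units; beyond the scatter), follows the change nitro in place of phenyl on an aromatic carbon. Compound 3 gives 7870 nM in this assay, the highest of the two numbers shown; compound 2 stands nearest with a lower number beyond the scatter.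

Compound 4 `COc1ccc(C(=O)/C=C/c2cccc(O)c2)c2c1C=CC(C)(C)O2` is not yet measured. It differs from compound 3 by hydroxy in place of trifluoromethyl on an aromatic carbon. Among the measured compounds shown here, no measured step involves a hydroxy or a trifluoromethyl, so the one recorded step, nitro in place of phenyl, does not bear on this exchange. From compound 3 the expected step in this assay is a 1.2-fold lower number from compound 3 to compound 4 (0.08 log units; within the scatter), not beyond the scatter in either direction. Compound 4 is therefore estimated at 6500 nM, with a range from 2500 nM to 16000 nM.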

Compound 4, half-maximal inhibitory concentration: > 10000 nM
Compound 4: no number, only a limit; the forecaster's own chance of this, stated with the estimate: 30%; middle value at least 1.5-fold (0.18 log units) away from the limit.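

In this assay compound 4 gives > 10000 nM as a limit of the assay and not a number. Hydroxy in place of trifluoromethyl, on an aromatic carbon meta to a large group, gives an at least 1.2-fold higher number from compound 3 to compound 4 (0.10 log units; that floor lies within the scatter) and brings no gain at this position, while the true size of the step stays unread. 3-hydroxyphenyl in place of 4-nitrophenyl gives an at least 2.8-fold higher number from compound 2 to compound 4 (0.45 log units; beyond the scatter) and leaves the series with a second compound at the upper end of the read-out: the limit of > 10000 nM in this assay, at which 2 of the 4 values shown sit.

The compounds shown leave open whether an amine or a carboxylic acid on this aromatic ring would bring the number below the limit, and whether hydroxy on another carbon of the ring would read differently. How far compound 4 lies from compound 1 cannot be read, as both values are limits.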